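The compounds below may be only part of what the source reports. "The series", "measured", "known", "first", "only" and "open" are said of these compounds alone.

Compound 1 `O=C(/C=C/c1ccc2c(c1)B(O)OC2)c1ccc(C(F)(F)F)cc1`: in an ADME assay on L929 cells (Mus musculus) for cytotoxicity, read by resazurin assay, with a stated time of 72 h (on this read-out higher numbers stand for weaker inhibition and lower numbers for stronger inhibition), compound 1 gives > 10 ug/mL, which is a limit of the assay and not a number.
Compound 2 `O=C(O)c1ccc(C(=O)/C=C/c2ccc3c(c2)B(O)OC3)cc1`: in this assay compound 2 gives > 10 ug/mL, again a limit rather than a number.
Compound 3 `O=C(/C=C/c1ccc2c(c1)B(O)OC2)c1cccs1`: in this assay compound 3 gives > 10 ug/mL, also a limit.

Compound 2 therefore stands only at a limit, and it shares that limit with both other measured compounds: the limit of > 10 ug/mL in this assay, at which 3 of the 3 values shown sit. Going by the values given here, the one measured step that changes a single place, a step that the two limits leave unreadable from compound 1 to compound 2, cannot be read because both ends sit at that limit.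

The unmeasured compound 4 `O=C(/C=C/c1ccc2c(c1)B(O)OC2)c1ccc(Cl)cc1` differs from compound 2 in one place: chloro in place of carboxy on an aromatic carbon. Among the compounds with values here, the only step that bears on this change is the one from compound 1 to compound 2, and its size is not readable. Within the data shown here, no measured step points in either direction, so no change beyond the scatter is expected in this assay; the most likely outcome is that compound 4 also sits at the limit.

Compound 4 is therefore estimated at 20 ug/mL, within a range from 8 ug/mL to 60 ug/mL, which means an expected step that the limit leaves unreadable from compound 2 to compound 4 from compound 2.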

Compound 4, half-maximal inhibitory concentration: > 10 ug/mL
Compound 4: only a limit was reported (the forecaster's own chance of this, stated with the estimate: 85%); the middle value lies beyond the limit too.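

None of the steps from compound 1, compound 2 or compound 3 to compound 4 can be read, because all four compounds sit at one limit, which is not a number: the limit of > 10 ug/mL in this assay, at which 4 of the 4 values shown sit.

The compounds shown leave open where each truly lies beyond that limit, and so whether swapping these groups changes cytotoxicity at all.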